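This account rests on a few compounds, and the source may have more. Where it says the series, first, only, none or still open, it means among the compounds named here.

Of the compounds shown here, three with a shared core have been measured in a functional assay on U-251 cells (Homo sapiens) for cytotoxicity; a higher number here means a weaker inhibitor of growth, a lower number a stronger inhibitor of growth. Compound 1 `COc1ccc(C2=C(c3cc(OC)c(OC)c(OC)c3)CC3CCCN3C2=O)cc1O` gives > 100000 nM there, and that value is a limit of the assay. Of the two true numbers, compound 2 `COc1ccc(C2=C(c3ccc(SC)cc3)CC3CCCN3C2=O)cc1OC(=O)C1CCCN1C(=O)OC(C)(C)C` reads 2000 nM, while compound 3 `CSc1ccc(C2=C(c3ccc(F)c(F)c3)C(=O)N3CCCC3C2)cc1` reads 15000 nM. Compound 3 thus has the higher number of the pair and is the weaker growth inhibitor, by a gap beyond the usual scatter. Compound 4 `COc1ccc(C2=C(c3ccc(SC)cc3)CC3CCCN3C2=O)cc1` differs from compound 3 by one change on a double-bonded ring carbon, next to the ring atom that bears a 4-(methylsulfanyl)phenyl group: 4-methoxyphenyl in place of 3,4-difluorophenyl (4-methoxyphenyl in place of 3,4-difluorophenyl on a double-bonded ring carbon). Going by the values given here, no measured pair shows this change alone, so its size can only be judged from the nearest neighbour. Compound 2, which also has a methoxy-bearing ring in that place, reads 2000 nM in this assay. A move toward a lower number, beyond the scatter, is therefore expected, and the estimated step is a 3.0-fold lower number from compound 3 to compound 4 (0.48 log units; beyond the scatter). For compound 4 the expected value is 5000 nM, with an estimated range from 1200 nM to 20000 nM.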

Compound 4, concentration for 50% growth inhibition: 2000 nM
For compound 4 the middle estimate is 2.5-fold (0.40 log units) above the measured one; low and high end bracket the measured number.
By their numbers in this assay, from the lowest: compounds 2 and 4 (each within the scatter of the next); then compound 3. At a limit, above all of these: compound 1.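

Before compound 4, no pair isolated this double-bonded ring carbon; in this assay the change to 4-methoxyphenyl gives a 7.5-fold lower number from compound 3 to compound 4 (0.88 log units; beyond the scatter) with the 4-(methylsulfanyl)phenyl group held in place, so this position does respond to the group it carries. Compound 4 also brings a second comparison: without the extra group on the methoxy-bearing ring, compound 4 reads 2000 nM in this assay, while compound 2 reads 2000 nM there, the same printed value. Nothing in the data shown explains why this step occurs.

As far as these compounds go, whether the gain comes from losing the two fluorines or from gaining the methoxy group stays open, since both happen in this one change. From the compounds shown here alone, how a plain phenyl ring, or a ring carrying an amine or a carboxylic acid, would read at this carbon also remains unknown.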